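Chloro to methyl on the triazole aryl of compound 1

This account rests on a few compounds, and the source may have more. Where it says the series, first, only, none or still open, it means among the compounds named here.

Compound 1 `C=C1C[C@]23C[C@@]1(O)CC[C@H]2c1ccc(OS(=O)(=O)c2ccc(C)cc2)c(C)c1[C@@H]3Cn1cc(-c2ccc(Cl)cc2)nn1` has been run in a functional assay on HL-60 cells (Homo sapiens) for cytotoxicity, read by MTT assay, with a stated time of 4 days; a higher number here means a weaker inhibitor, a lower number a stronger inhibitor. In this assay compound 1 gives > 20000 nM, which is a limit of the assay and not a number. Compound 2 `Cc1c(O)ccc2c1[C@H](Cn1cc(-c3ccc(F)cc3)nn1)[C@@]13CC(=O)[C@@](C)(CC[C@@H]21)C3`, built on a different core, has also been run in this assay. Compound 2 gives > 20000 nM, again a limit rather than a number. For the measured compounds named here, compound 1 therefore stands at the limit, as do all values shown (the limit of > 20000 nM in this assay, at which 2 of the 2 values shown sit); no measured step joins the two compounds, and the pair shows only that neither reached a measurable value.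

Compound 3 `C=C1C[C@]23C[C@@]1(O)CC[C@H]2c1ccc(OS(=O)(=O)c2ccc(C)cc2)c(C)c1[C@@H]3Cn1cc(-c2ccc(C)cc2)nn1` is to be measured in this assay. It differs from compound 1 in one place: methyl in place of chloro on an aromatic carbon. Going by the values given here, no step between measured compounds bears on this change. Since compound 1 sits at the limit (the limit of > 20000 nM in this assay, at which 2 of the 2 values shown sit), there is no measurable starting point from which a shift could be read. The step is expected to be none beyond the usual scatter, a step that the limit leaves unreadable from compound 1 to compound 3. Compound 3 is accordingly expected to give about 30000 nM, within 10000 nM to 100000 nM, most likely reported once more only as a limit.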

Compound 3, half-maximal inhibitory concentration: > 20000 nM
Compound 3: no number, only a limit; the forecaster's own chance of this, stated with the estimate: 80%; the middle value is on the limit's open side.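

In this assay compound 3 gives > 20000 nM, which is a limit of the assay and not a number. No step can be read between compound 1 and compound 3, as both stand at a limit: the limit of > 20000 nM in this assay, at which 3 of the 3 values shown sit.

The compounds shown leave open what the change from 4-chlorophenyl to 4-methylphenyl does on a compound with a measurable value in this assay.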